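The source may report more compounds than this note shows. Statements on the series, on what has been measured and on what is new or still open speak of the compounds shown alone.

Working notes on the series in a functional assay on MCF7 cells (Homo sapiens) for antiproliferative activity; on this read-out lower numbers stand for stronger inhibition and higher numbers for weaker inhibition. Compound 1 `COc1cccc(Oc2ccc3cc(NC(=O)c4ccc(O)c(CC=C(C)C)c4)c(=O)oc3c2C)c1` gives 62800 nM in this assay. Compound 2 `CC(C)=CCc1cc(C(=O)Nc2cc3ccc(Oc4ccc(C(C)(C)C)cc4)c(C)c3oc2=O)ccc1O` carries 4-(tert-butyl)phenyl in place of 3-methoxyphenyl on an oxygen on an aromatic ring and gives 20600 nM in this assay; the measured step is a 3.0-fold lower number from compound 1 to compound 2 (0.48 log units; beyond the scatter). Compound 3 `COc1cccc(Oc2ccc3cc(NC(=O)c4ccc(OC)c(-c5cccc(OC)c5)c4)c(=O)oc3c2C)c1` differs from compound 1 on the amide side; how the core of compound 3 differs from the core of compound 1 is not broken down here. In this assay compound 3 reaches only a limit of the assay, > 100000 nM. Compound 4 `COc1cccc(-c2cc(C(=O)Nc3cc4ccc(Oc5ccc(C(C)(C)C)cc5)c(C)c4oc3=O)ccc2OC)c1` has not yet been measured and differs from compound 3 by 4-(tert-butyl)phenyl in place of 3-methoxyphenyl on an oxygen on an aromatic ring, the same change as from compound 1 to compound 2, at the same place. Because that change gave a 3.0-fold lower number from compound 1 to compound 2 (0.48 log units; beyond the scatter), a step of similar size is expected for compound 4, namely an at least 1.4-fold lower number from compound 3 to compound 4 (0.15 log units; that floor lies within the scatter). The starting point for compound 3 is only a limit (the limit of > 100000 nM in this assay, at which 1 of the 3 values shown sits), so the expected value for compound 4 rests on a floor rather than a number. Compound 4 is expected to give about 70000 nM in this assay, within 25000 nM to 200000 nM.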

Compound 4, half-maximal inhibitory concentration: > 100000 nM
Compound 4 gave a limit, no number; the forecaster's own chance of this, stated with the estimate: 40%; middle value at least 1.4-fold (0.15 log units) away from the limit.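

In this assay compound 4 reaches only a limit of the assay, > 100000 nM and compound 3 also sits at a limit, so no step can be read from compound 3 to compound 4: the limit of > 100000 nM in this assay, at which 2 of the 4 values shown sit.

From the compounds shown here alone, whether 4-(tert-butyl)phenyl in place of 3-methoxyphenyl lowers the number with the amide side of compound 3, as it does from compound 1 to compound 2, stays open.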